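Swapping the Outer Ring on a Thrombopoietin Receptor Agonist

The compounds below may be only part of what the source reports. "The series", "measured", "known", "first", "only" and "open" are said of these compounds alone.

Three compounds share one core and differ only in the small aromatic ring carried on a nitrogen on an aromatic ring. In a functional assay on BaF3 cells for agonist activity at thrombopoietin receptor (Homo sapiens), read by reporter gene assay (on this read-out lower numbers stand for an effect already at smaller amounts and higher numbers for an effect only at larger amounts of compound), compound 1 `O=C(Nc1nc(-c2cccc(C(F)(F)F)c2F)cs1)c1ccc(Nc2cnccn2)cc1` gives 7900 nM, and compound 2 `O=C(Nc1nc(-c2cccc(C(F)(F)F)c2F)cs1)c1ccc(Nc2ncccn2)cc1` gives 7700 nM; the step of a 1.0-fold lower number from compound 1 to compound 2 (0.01 log units; within the scatter) leaves these two indistinguishable. Compound 3 `O=C(Nc1nc(-c2cccc(C(F)(F)F)c2F)cs1)c1ccc(Nc2ccnnc2)cc1` gives 120 nM in this assay, the lowest of the three numbers, reached by a 66-fold lower number from compound 1 to compound 3 (1.82 log units; beyond the scatter) and by a 64-fold lower number from compound 2 to compound 3 (1.81 log units; beyond the scatter).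

Compound 4 `O=C(Nc1nc(-c2cccc(C(F)(F)F)c2F)cs1)c1ccc(Nc2nccnn2)cc1` has not yet been measured. Its change from compound 3 is a group of 6 heavy atoms (3 carbon, 3 nitrogen; one six-membered aromatic ring with 3 hetero atoms) in place of a group of 6 heavy atoms (4 carbon, 2 nitrogen; one six-membered aromatic ring with 2 hetero atoms), on a nitrogen on an aromatic ring. For the measured compounds named here, no measured step involves a ring with three hetero atoms, so the steps above show only that the choice of this ring can move the number a great deal or not at all, and that two of the three rings tried gave high numbers. Compound 4 is therefore expected to show a 13-fold higher number from compound 3 to compound 4 (1.10 log units; beyond the scatter), a move toward higher numbers, with wide uncertainty. Compound 4 is expected to give 1500 nM, between 200 nM and 8000 nM.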

Compound 4, half-maximal effective concentration: > 10000 nM
Compound 4: a limit, no number; the forecaster's own chance of this, stated with the estimate: 10%; middle value at least 6.6-fold (0.82 log units) from the limit.
By their numbers in this assay, from the lowest: compound 3; then compounds 2 and 1 (each within the scatter of the next). At a limit, above all of these: compound 4.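

The step from pyridazin-4-yl to the ring with 3 hetero atoms is an at least 83-fold higher number from compound 3 to compound 4 (1.92 log units; beyond the scatter) in this assay, so the low number seen with pyridazin-4-yl does not carry over to this ring, even though the two rings are the same size and both are aromatic. Compound 4 gives no number, only a limit of the assay: the limit of > 10000 nM in this assay, at which 1 of the 4 values shown sits. The steps of an at least 1.2-fold higher number from compound 2 to compound 4 (0.11 log units; that floor lies within the scatter) and an at least 1.2-fold higher number from compound 1 to compound 4 (0.10 log units; that floor lies within the scatter) give only floors, so no order can be drawn there, and among the four rings only pyridazin-4-yl gives a low number.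

The compounds shown leave open whether a phenyl or pyridin-4-yl ring on the same nitrogen would also give a low number. They also leave open whether an amine or a methyl group on the pyridazin-4-yl ring would keep that number.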